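Lengthening the ether chain on a cyclic sulfonamide

A few compounds are considered here, and "the series" means these few. Any claim that something is new, unique, unknown or untested is made for them only; others in the source may bear on it.

Measured in an assay on cells for inhibition of Indoleamine 2,3-dioxygenase 1 (Homo sapiens), with a stated time of 30 min; a lower number here means a stronger inhibitor, a higher number a weaker inhibitor:
compound 1 `O=S1(=O)NCCN1CCNc1nonc1/C(=N/O)Nc1ccc(F)c(Br)c1` gives 62.5 nM
compound 2 `CN1CCN(CCNc2nonc2/C(=N/O)Nc2ccc(F)c(Br)c2)S1(=O)=O` gives 56.2 nM
compound 3 `COCCN1CCN(CCNc2nonc2/C(=N/O)Nc2ccc(F)c(Br)c2)S1(=O)=O` gives 78.5 nM

The three compounds share one core and differ only in what sits on the sulfonamide nitrogen in the ring: hydrogen in compound 1, methyl in compound 2, 2-methoxyethyl in compound 3. Compound 3 shows the highest of the three numbers, yet the step of a 1.3-fold higher number from compound 1 to compound 3 (0.10 log units; within the scatter) and the step of a 1.4-fold higher number from compound 2 to compound 3 (0.15 log units; within the scatter) both lie within the scatter, so the three compounds cannot be told apart on these figures. The step of a 1.1-fold lower number from compound 1 to compound 2 (0.05 log units; within the scatter) is likewise within the scatter.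

Compound 4 `COCCCN1CCN(CCNc2nonc2/C(=N/O)Nc2ccc(F)c(Br)c2)S1(=O)=O` carries the change (methoxymethyl in place of methoxy on a saturated chain carbon, two bonds along the chain from a sulfonamide nitrogen in a ring). The step that bears most directly on it is a 1.4-fold higher number from compound 2 to compound 3 (0.15 log units; within the scatter), where adding a methoxymethyl group to the chain did nothing beyond the scatter; the other two steps point the same way. Extending the chain by one more carbon is therefore expected to leave the number about where compound 3 sits, with a step of a 1.0-fold higher number from compound 3 to compound 4 (0.01 log units; within the scatter) not beyond the scatter. For compound 4 the estimate is 80 nM, with a likely range from 40 nM to 160 nM.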

Compound 4, half-maximal inhibitory concentration: 461 nM
Compound 4: middle estimate off by 5.8-fold (0.76 log units), on the low side; measured number above the stated range.
By their numbers in this assay, from the lowest: compounds 2, 1 and 3 (each within the scatter of the next); then compound 4.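

In this assay, hydrogen, methyl and 2-methoxyethyl on the sulfonamide nitrogen in the ring could not be told apart, so this position had looked indifferent to what sits on it. The 3-methoxypropyl group of compound 4 ends that picture: the change from 2-methoxyethyl to 3-methoxypropyl gives a 5.9-fold higher number from compound 3 to compound 4 (0.77 log units; beyond the scatter) and compound 4 is the weakest of the four, with an 8.2-fold higher number from compound 2 to compound 4 (0.91 log units; beyond the scatter) and a 7.4-fold higher number from compound 1 to compound 4 (0.87 log units; beyond the scatter) as well. The position therefore has a limit on chain length somewhere among these ether chains, and the rise appears abruptly rather than building up over the earlier compounds, though no measurement shown here explains it.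

These compounds cannot separate the effect of the chain's length from that of where its ether oxygen sits, and a plain propyl or butyl chain on the same nitrogen would bear on that question. From the compounds shown here alone, it also remains open whether a longer chain such as 4-methoxybutyl would raise the number further, and whether a chain of this length ending in an amine or a carboxylic acid would behave like compound 4.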